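This account rests on a few compounds, and the source may have more. Where it says the series, first, only, none or still open, it means among the compounds named here.

Of the compounds shown here, three sharing one core have been tested in a functional assay on MIA PaCa-2 cells (Homo sapiens) for cytotoxicity, read by MTT assay, with a stated time of 24 h (on this read-out lower numbers stand for stronger inhibition and higher numbers for weaker inhibition), and they differ only in the hydroxyl-bearing group at one end. Compound 1 (`CC[C@H](C)[C@@H](O)C(=O)O[C@@H](C(=O)O[C@@H](C(=O)O[C@@H](C(=O)O[C@@H](C(=O)OC[C@@H](O)[C@@H](O)CO)[C@@H](C)CC)[C@@H](C)CC)[C@@H](C)CC)[C@@H](C)CC`) gives > 57800 nM, which is a limit. Compound 2 (`CC[C@H](C)[C@@H](O)C(=O)O[C@@H](C(=O)O[C@@H](C(=O)O[C@@H](C(=O)O[C@@H](C(=O)O[C@@H]([C@H](O)[C@H](O)CO)[C@H](O)CO)[C@@H](C)CC)[C@@H](C)CC)[C@@H](C)CC)[C@@H](C)CC`) gives > 53200 nM, also a limit. Compound 3 (`CC[C@H](C)[C@@H](O)C(=O)O[C@@H](C(=O)O[C@@H](C(=O)O[C@@H](C(=O)O[C@@H](C(=O)O[C@H](CO)[C@@H](O)[C@H](O)[C@H](O)CO)[C@@H](C)CC)[C@@H](C)CC)[C@@H](C)CC)[C@@H](C)CC`) gives > 53200 nM, again a limit, so it has no exact number, and neither do the other two.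

Compound 4 (`CC[C@H](C)[C@@H](O)C(=O)O[C@@H](C(=O)O[C@@H](C(=O)O[C@@H](C(=O)O[C@@H](C(=O)O[C@H](CO)[C@@H](O)[C@H](O)CO)[C@@H](C)CC)[C@@H](C)CC)[C@@H](C)CC)[C@@H](C)CC`) differs from compound 3 by one change, hydrogen in place of hydroxymethyl on a saturated chain carbon bound to an oxygen on a saturated carbon and a saturated chain carbon. The measured steps that bear on this change all altered the same end of the molecule. They are a step that the two limits leave unreadable from compound 1 to compound 3, a step that the two limits leave unreadable from compound 2 to compound 3 and a step that the two limits leave unreadable from compound 1 to compound 2. None of them has a readable size, so no step beyond the scatter is expected in this assay, in either direction, and another limit is the likely result. The expected outcome is a step that the limit leaves unreadable from compound 3 to compound 4. The estimate for compound 4 is 55000 nM, with an expected range from 30000 nM to 100000 nM.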

Compound 4, half-maximal inhibitory concentration: 36400 nM
The estimate for compound 4 lay 1.5-fold (0.18 log units) above the measured number; the measured number falls inside the stated range.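

Among compound 1, compound 2 and compound 3, no step could be read, but compound 4 has an exact number, so this change gives the first readable steps at this end of the molecule: hydrogen in place of hydroxymethyl on a saturated chain carbon gives an at least 1.4-fold lower number from compound 3 to compound 4 (0.16 log units; that floor lies within the scatter). The same end compared with the other two compounds gives an at least 1.4-fold lower number from compound 2 to compound 4 (0.16 log units; that floor lies within the scatter) and an at least 1.5-fold lower number from compound 1 to compound 4 (0.20 log units; that floor lies within the scatter). These are floors rather than full sizes, and none yet shows a real change, because the starting values are limits, as here: the limit of > 53200 nM in this assay, at which 2 of the 4 values shown sit.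

Going by these compounds, how large the true steps are stays open. Also open, on these data alone, is whether an amine or a carboxylic acid in place of the hydroxymethyl would give a step beyond the scatter.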